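This account rests on a few compounds, and the source may have more. Where it says the series, first, only, none or still open, it means among the compounds named here.

Compound 1, `COc1ccc(SCc2ccc(/C=C/C(=O)Nc3ccccc3N)cc2)cc1OC`: 21.9%
Compound 2, `Nc1ccccc1NC(=O)c1ccc(CSc2nccc(C(F)(F)F)n2)cc1`: 83.4%
Compound 3, `Nc1ccccc1NC(=O)c1ccc(CSc2ccc(C(F)(F)F)cn2)cc1`: 16.5%

Among these three numbers from a functional assay on HeLa cells (Homo sapiens) for inhibition, read by CCK-8 assay, with a stated time of 72 h, tested at 8 uM (on this read-out higher numbers stand for more inhibition of growth at the one concentration tested and lower numbers for less inhibition of growth), compound 1 stands second highest. Its number lies close to that of compound 3, within the usual scatter, so the two cannot be told apart, while compound 2 gives a far higher number, well beyond the scatter. Compound 4, `Cc1cc(C)cc(SCc2ccc(/C=C/C(=O)Nc3ccccc3N)cc2)c1`, keeps the whole core of compound 1 and alters only one part: 3,5-dimethylphenyl in place of 3,4-dimethoxyphenyl on a sulfur. Within the data shown here, no measured pair shows what such an exchange does here, so the size of its effect cannot be read from the three numbers. In the absence of such guidance, the step is expected to be small, in no clear direction, and not beyond the scatter: a number 3.1 percentage points higher from compound 1 to compound 4 (within the scatter). Compound 4 is therefore estimated at 25%, with a range from 8% to 45%.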

Compound 4, percent growth inhibition at one concentration: 3.39%
Beside the measured number, compound 4's estimate is 21.6 percentage points above it; the measured number lies below the stated range.
By their numbers in this assay, from the lowest: compound 4; then compounds 3 and 1 (each within the scatter of the next); then compound 2.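

In this assay, placing 3,5-dimethylphenyl on the sulfur in place of 3,4-dimethoxyphenyl gives a number 18.5 percentage points lower from compound 1 to compound 4 (beyond the scatter), so this position does respond to a change of group. The exchange alters both the ring's substituents and their arrangement, and this one step cannot separate those two changes. Nothing available explains the fall. As far as these compounds go, it remains open whether the oxygen atoms or the arrangement of the groups matters more. A phenyl ring carrying a single methoxy group, an amine or a carboxylic acid could help separate these possibilities.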